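The source may hold more compounds than are shown below. What is called first, only, known or untested is meant among the compounds shown, and "the series" means these compounds.

Measured in a functional assay (aorta) with Rattus norvegicus as the target; on this read-out lower numbers stand for stronger inhibition and higher numbers for weaker inhibition:
- compound 1 `CCCCc1cn2ccccc2c1S(=O)(=O)c1ccc(OCCCN(CCCC)CCCC)cc1`: 284 nM
- compound 2 `CCCCN(CCCC)CCCOc1ccc(S(=O)(=O)c2c(C3CCCCC3)cn3ccccc23)cc1`: 4070 nM
- compound 3 `CCCCN(CCCC)CCCOc1ccc(S(=O)(=O)c2c(-c3ccccc3)cn3ccccc23)cc1`: 1620 nM

Among these three, compound 3 holds the second highest number (1620 nM), with compound 1 lower and compound 2 higher. The next compound, compound 4 `CCCCN(CCCC)CCCOc1ccc(S(=O)(=O)c2c(C)cn3ccccc23)cc1`, carries methyl in place of phenyl on an aromatic carbon.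

All three measured steps concern this same carbon. Going from butyl to phenyl gave a modest step (a 5.7-fold higher number from compound 1 to compound 3 (0.76 log units; beyond the scatter)). Going from butyl to cyclohexyl gave a large one (a 14-fold higher number from compound 1 to compound 2 (1.16 log units; beyond the scatter)). Going from cyclohexyl to phenyl gave a modest one (a 2.5-fold lower number from compound 2 to compound 3 (0.40 log units; beyond the scatter)).

So the two groups with a ring both give higher numbers than the open chain of compound 1, which stands at 284 nM, though only three groups have been compared. Methyl also has no ring, which points toward the lower end of this small series. No group as small as methyl has been measured here, however, so the range stays wide.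

In this assay, a modest step toward a lower number is expected (a 2.7-fold lower number from compound 3 to compound 4 (0.43 log units; beyond the scatter)). For compound 4 the estimated value is 600 nM, with an expected range from 150 nM to 2200 nM.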

Compound 4, half-maximal inhibitory concentration: 162 nM
For compound 4 the middle estimate is 3.7-fold (0.57 log units) above the measured one, within the range that was stated.
By their numbers in this assay, from the lowest: compounds 4 and 1 (each within the scatter of the next); then compound 3; then compound 2.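

In this assay methyl in place of phenyl gives a 10-fold lower number from compound 3 to compound 4 (1.00 log units; beyond the scatter) and methyl in place of cyclohexyl gives a 25-fold lower number from compound 2 to compound 4 (1.40 log units; beyond the scatter) and both steps lie beyond the scatter, which shows that this aromatic carbon of the five-membered ring tolerates a group as small as methyl without the loss seen with either ring. The step between the two open groups, a 1.8-fold lower number from compound 1 to compound 4 (0.24 log units; within the scatter) and so within the scatter, shows that compound 4 and compound 1 cannot be told apart, which means that going from butyl down to methyl brings no readable change. Across the four groups now compared, both groups with a ring give higher numbers than both groups without one, and no compound shown goes against this.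

The compounds shown leave open whether hydrogen at this carbon, an ethyl or propyl chain, or a chain longer than butyl would stay with methyl and butyl, and whether a ring as small as cyclopropyl would side with phenyl and cyclohexyl. Nothing measured here explains the gap between the groups with a ring and those without.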